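This account rests on a few compounds, and the source may have more. Where it says the series, first, only, none or still open, it means among the compounds named here.

Working notes on the series. For the measured compounds named here, in a functional assay on SiHa cells (Homo sapiens) for inhibition, read by sulforhodamine B assay (on this read-out higher numbers stand for weaker inhibition of growth and lower numbers for stronger inhibition of growth), compound 1 `Cc1ccc2[nH]c(-c3ccc(-c4ccc(-c5ccc(N(C)C)cc5)cc4)cc3)nc2c1` gives 7110 nM, the higher of the two numbers available so far, while compound 2 `COc1ccc(-c2ccc(-c3ccc(-c4nc5cc(C)ccc5[nH]4)cc3)cc2)cc1OC` gives 3510 nM. The next compound to be read is compound 3 `CN(C)c1ccc(-c2ccc(-c3ccc(-c4nc5c(O)cccc5[nH]4)cc3)cc2)cc1`, in which 4-hydroxy-1H-benzimidazol-2-yl stands in place of 5-methyl-1H-benzimidazol-2-yl: 4-hydroxy-1H-benzimidazol-2-yl in place of 5-methyl-1H-benzimidazol-2-yl on an aromatic carbon. Going by the values given here, only one measured step exists, a 2.0-fold lower number from compound 1 to compound 2 (0.31 log units; beyond the scatter), a modest move that puts 3,4-dimethoxyphenyl in place of 4-(dimethylamino)phenyl. Compound 3 keeps the 4-(dimethylamino)phenyl group, so that step bears on this change only indirectly, as a rough guide to how far one swap can move the number in this series. Among the compounds with values here, no measured pair changes the benzimidazolyl group, which leaves the direction open. In this assay, no shift beyond the scatter is therefore expected, and the estimated step is a 1.3-fold lower number from compound 1 to compound 3 (0.11 log units; within the scatter), with a slightly lower number only a weak guess. For compound 3 the expected value is 5500 nM, with an estimated range from 2200 nM to 13000 nM.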

Compound 3, concentration for 50% growth inhibition: 6240 nM
For compound 3 the middle estimate is 1.1-fold (0.05 log units) below the measured one; low and high end bracket the measured number.
By their numbers in this assay, from the lowest: compounds 2, 3 and 1 (each within the scatter of the next, the first and the last beyond it).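

In this assay, for the compounds shown here, the first measured change to the benzimidazolyl group gives a 1.1-fold lower number from compound 1 to compound 3 (0.06 log units; within the scatter), so with 4-(dimethylamino)phenyl kept, the two groups cannot be told apart on this read-out. Going by these compounds alone, the entering group has 2 hydrogen-bond donors and 2 hydrogen-bond acceptors, against 1 of each in the leaving group, and this difference in counts comes with no shift beyond the scatter in this single pair, while the one step beyond the scatter remains a 2.0-fold lower number from compound 1 to compound 2 (0.31 log units; beyond the scatter), which changes the 4-(dimethylamino)phenyl group instead. No evidence is available that bears on this result.

The compounds shown leave open whether an amine, a carboxylic acid or a methoxy group on the benzimidazolyl ring would move the number beyond the scatter, and whether 4-hydroxy-1H-benzimidazol-2-yl and 5-methyl-1H-benzimidazol-2-yl would also read alike with 3,4-dimethoxyphenyl in place of 4-(dimethylamino)phenyl. On these data alone, this pair also changes the group and its place together, so 5-hydroxy-1H-benzimidazol-2-yl and 4-methyl-1H-benzimidazol-2-yl remain open as the compounds that would separate the two changes.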